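This account rests on a few compounds, and the source may have more. Where it says the series, first, only, none or still open, it means among the compounds named here.

Working notes on the series, read in a physicochemical assay for solubility, in phosphate buffer, at pH 7.4; a higher number here means a more soluble compound, a lower number a less soluble compound. Compound 1 (`CCNC(=O)Nc1nc2cc(-c3cccnc3)c(=O)n(CC3CCCCC3)c2s1`) gives 7000 nM, compound 2 (`CCNC(=O)Nc1nc2cc(-c3cccnc3)c(=O)n(CC3CCOCC3)c2s1`) gives 25000 nM, and compound 3 (`CCNC(=O)Nc1nc2cc(-c3cncnc3)c(=O)n(C(C)C)c2s1`) gives 7000 nM. Compound 3 is thus level with compound 1, the pair sharing the lowest number of the three, and it lies under compound 2.

Compound 4 (`CCNC(=O)Nc1nc2cc(-c3cncc(C#N)c3)c(=O)n(C(C)C)c2s1`) has 5-cyanopyridin-3-yl in place of pyrimidin-5-yl on an aromatic carbon of compound 3: 5-cyanopyridin-3-yl in place of pyrimidin-5-yl on an aromatic carbon.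

Within the data shown here, no measured step covers a change at this aromatic carbon. Among the measured compounds shown here, the only step available is a 3.6-fold higher number from compound 1 to compound 2 (0.55 log units; beyond the scatter), a modest one, with oxan-4-yl in place of cyclohexyl at a different place on the core. It bears on the new change only as a rough guide to how far one substitution moves this series. No shift beyond the scatter is expected, with a slight fall at most. The expected change is a 1.4-fold lower number from compound 3 to compound 4 (0.15 log units; within the scatter). For compound 4 the estimated value is 5000 nM, with an expected range of 1800 nM to 14000 nM.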

Compound 4, solubility: < 5000 nM
Compound 4: a limit, no number; the forecaster's own chance of this, stated with the estimate: 5%; the middle value lies on the limit itself.
By their numbers in this assay, from the lowest: compounds 1 and 3 (each within the scatter of the next); then compound 2. At a limit, below all of these: compound 4.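

At this aromatic carbon, two atoms from the ring nitrogen, the series now has its first reading: in this assay, 5-cyanopyridin-3-yl in place of pyrimidin-5-yl gives an at least 1.4-fold lower number from compound 3 to compound 4 (0.14 log units; that floor lies within the scatter). The result for compound 4 is a limit of the assay and not a number: the limit of < 5000 nM in this assay, at which 1 of the 4 values shown sits. The step therefore has only a floor, and that floor within the scatter does not settle whether the true fall is small or large.

The compounds shown leave open how far compound 4 lies under its limit, and how much of the step belongs to the entering nitrile and how much to the ring with one hetero atom in place of two. Also open, from the compounds shown here alone, is how a morpholine or a carboxylic acid on the ring at this aromatic carbon would read in this assay.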